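From Methoxymethyl to Propoxymethyl: Expecting Compound 4

The source may hold more compounds than are shown below. What is called first, only, known or untested is meant among the compounds shown, and "the series" means these compounds.

The compounds measured so far in a functional assay on KB cells (Homo sapiens) for cytotoxicity, read by MTT assay, with a stated time of 72 h (a higher number here means a weaker inhibitor, a lower number a stronger inhibitor), are:
compound 1, `O=[N+]([O-])c1cccc(COCNc2n[n+]([O-])c3ccccc3[n+]2[O-])c1`, 580 nM
compound 2, `COCNc1n[n+]([O-])c2ccccc2[n+]1[O-]`, 1580 nM
compound 3, `CC(OCNc1n[n+]([O-])c2ccccc2[n+]1[O-])c1ccccc1`, 2510 nM

Compound 2 stands second highest of these three numbers. Its nearest neighbour is compound 3, whose value lies within the scatter of that of compound 2, so nothing can be said of an order between them. Its furthest neighbour is compound 1, whose value is lower than that of compound 2 by a gap beyond the scatter.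

Compound 4, `CCCOCNc1n[n+]([O-])c2ccccc2[n+]1[O-]`, has not yet been measured in this assay. It differs from compound 2 by ethyl in place of hydrogen on a saturated chain carbon bound to an oxygen on a saturated carbon. Among the compounds with values here, no step between two measured compounds that differ in one place is available, so the expectation for this change rests only on the three numbers above. Of the two compounds that carry a larger group at this place, compound 1 gives a lower number beyond the scatter, and compound 3 gives a number within the scatter of compound 2. Taken together, they give no single direction, and the step is expected to be small, in neither direction beyond the scatter: a 1.1-fold lower number from compound 2 to compound 4 (0.05 log units; within the scatter). Compound 4 is therefore estimated at 1400 nM, with a range from 600 nM to 3500 nM.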

Compound 4, half-maximal inhibitory concentration: 1950 nM
Beside the measured number, compound 4's estimate is 1.4-fold (0.14 log units) below it; measured number inside the range.
By their numbers in this assay, from the lowest: compound 1; then compounds 2, 4 and 3 (each within the scatter of the next).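

In this assay, within the data shown here, the change from methoxymethyl to propoxymethyl gives the first step at this position that can be read directly: a 1.2-fold higher number from compound 2 to compound 4 (0.09 log units; within the scatter). Ethyl in place of hydrogen on a saturated chain carbon bound to an oxygen on a saturated carbon therefore does not separate compound 4 from compound 2, so this open chain, which adds no ring, does not reproduce the gap that compound 1 shows at 580 nM. No accompanying measurement bears on this result. 

The compounds shown leave open whether a longer chain such as hexyl, or a chain ending in an amine or a carboxylic acid, would move the number beyond the scatter at this place. They also leave open how much of the gap of compound 1 belongs to its nitro group and how much to its benzene ring, a question that a plain benzyl group at the same place would address.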